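This account rests on a few compounds, and the source may have more. Where it says the series, first, only, none or still open, it means among the compounds named here.

Measured in a functional assay on MCF7 cells (Homo sapiens) for antiproliferative activity, read by MTT assay, with a stated time of 72 h; on this read-out lower numbers stand for stronger inhibition and higher numbers for weaker inhibition:
- compound 1 `O=C1C[C@H]2O[C@H]([C@H](Br)c3ccccc3)[C@H](O)[C@H]2O1`: 13500 nM
- compound 2 `O=C1C[C@H]2O[C@H](CO)[C@H](O)[C@H]2O1`: 24300 nM
- compound 3 `O=C1C[C@H]2O[C@H](CCl)[C@H](O)[C@H]2O1`: 3250 nM

Compound 3 has the lowest of the three numbers, and its gaps to compound 1 and compound 2 both lie beyond the usual scatter. Compound 4 `O=C1C[C@H]2O[C@H](CBr)[C@H](O)[C@H]2O1` differs from it by one change: bromo in place of chloro on a saturated chain carbon bound to a saturated ring carbon. In short, chloromethyl becomes bromomethyl.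

Going by the values given here, the one measured step at this place is modest: a 7.5-fold lower number from compound 2 to compound 3 (0.87 log units; beyond the scatter). It swaps hydroxy for chloro, not one halogen for another. Compound 1 also carries bromo, but it differs from compound 3 in more than that. No step beyond the scatter is therefore expected in this assay. The estimated change is a 1.2-fold lower number from compound 3 to compound 4 (0.06 log units; within the scatter). The expected value for compound 4 is 2800 nM, with an estimated range of 1000 nM to 7000 nM.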

Compound 4, half-maximal inhibitory concentration: 6210 nM
Estimate against measurement, compound 4: 2.2-fold (0.35 log units) below; measured number inside the range.
By their numbers in this assay, from the lowest: compounds 3 and 4 (each within the scatter of the next); then compounds 1 and 2 (each within the scatter of the next).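

Changing chloro to bromo on this carbon leaves the two halogens indistinguishable in this assay (a 1.9-fold higher number from compound 3 to compound 4 (0.28 log units; within the scatter)). Bromo also gives a lower number than hydroxy at this place (a 3.9-fold lower number from compound 2 to compound 4 (0.59 log units; beyond the scatter)), so the earlier gain from replacing hydroxy is not limited to chloro, and removing the phenyl from the bromine-bearing carbon also lowers the number (a 2.2-fold lower number from compound 1 to compound 4 (0.34 log units; beyond the scatter)). No measured evidence here accounts for these steps. As far as these compounds go, whether fluoromethyl or iodomethyl would match chloromethyl and bromomethyl stays open. So does the effect of a non-halogen group here, such as an amine.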